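Weighing a smaller selenium group against a longer sulfur chain

The source may report more compounds than this note shows. Statements on the series, on what has been measured and on what is new or still open speak of the compounds shown alone.

Compound 2 `OCC#CCSc1cnc2ccccc2c1SCC#CCO` gives 42.2 ug/mL in a functional assay on B16 cells (Mus musculus) for cytotoxicity, read by sulforhodamine B assay, with a stated time of 72 h (a lower number here means a stronger inhibitor, a higher number a weaker inhibitor), the higher of the two numbers measured, and compound 1 `OCC#CCSc1cnc2ccccc2c1[Se]CC#CCO` gives 4.3 ug/mL. The step of a 9.8-fold higher number from compound 1 to compound 2 (0.99 log units; beyond the scatter) is the only one recorded. Compound 3 `C[Se]c1c(SCC#CCO)cnc2ccccc12` changes compound 2 by a group of 2 heavy atoms (1 carbon, 1 selenium; no ring) in place of a group of 6 heavy atoms (4 carbon, 1 oxygen, 1 sulfur; no ring), on an aromatic carbon. Since selenium returns with this change, though in a shorter group than in compound 1, the step of a 9.8-fold higher number from compound 1 to compound 2 (0.99 log units; beyond the scatter) suggests the number may fall again, yet the chain is also much shortened, so only part of that recovery is expected. The estimate for compound 3 is 12 ug/mL, range 4 ug/mL to 35 ug/mL, meaning an expected step of a 3.5-fold lower number from compound 2 to compound 3 (0.55 log units; beyond the scatter).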

Compound 3, concentration for 50% inhibition: 5.8 ug/mL
Estimate against measurement, compound 3: 2.1-fold (0.32 log units) above; the measured number falls inside the stated range.
By their numbers in this assay, from the lowest: compounds 1 and 3 (each within the scatter of the next); then compound 2.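

In this assay, putting the short selenium group on this aromatic carbon, opposite the ring nitrogen, gives a 7.3-fold lower number from compound 2 to compound 3 (0.86 log units; beyond the scatter) in place of the sulfur chain. Hydrogen in place of 3-hydroxyprop-1-yn-1-yl on the selenium chain gives a 1.3-fold higher number from compound 1 to compound 3 (0.13 log units; within the scatter) and stays within the scatter, so among these compounds the numbers track the selenium atom, not the length of the chain on it. No evidence here gives a reason for this. From the compounds shown here alone, whether an amine or a plain longer carbon chain on selenium would keep this number remains open, as does the part played by the sulfur chain all three compounds share.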